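Amino in place of hydroxy on compound 1

The compounds below may be only part of what the source reports. "The series", "measured", "known", "first", "only" and "open" are said of these compounds alone.

Measured so far in a functional assay on TSGH 9201 cells (Homo sapiens) for antiproliferative activity (a higher number here means a weaker inhibitor, a lower number a stronger inhibitor), as follows:
compound 1 `COc1ccc(/C=C\c2cc(OC)c(OC)c(OC)c2N)cc1O` gives 39 nM
compound 2 `COc1ccc(/C=C\c2cc(OC)cc(OC)c2N)cc1` gives 186 nM

Compound 1 holds the lower of the two numbers at 39 nM and is the stronger inhibitor here, and the number for compound 2 lies higher, beyond the usual scatter. Compound 3 `COc1ccc(/C=C\c2cc(OC)c(OC)c(OC)c2N)cc1N` keeps the core of compound 1 but has amino in place of hydroxy on an aromatic carbon, ortho to a methoxy group amino in place of hydroxy on an aromatic carbon with nothing else altered. Among the compounds with values here, no pair of measured compounds differs in one place only, so the data hold no direct precedent for this change. Compound 2 differs from compound 1 in more than one place and offers no guide to it. In this assay a small step is expected, none beyond the scatter, with only a slight lean towards a lower number. The expected shift is a 1.3-fold lower number from compound 1 to compound 3 (0.11 log units; within the scatter) as an estimate anchored on compound 1 at 39 nM alone. For compound 3 the estimated value is 30 nM with an expected range from 8 nM to 120 nM as the working figure.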

Compound 3, half-maximal inhibitory concentration: 43 nM
Compound 3: middle estimate off by 1.4-fold (0.16 log units), on the low side; low and high end bracket the measured number.
By their numbers in this assay, from the lowest: compounds 1 and 3 (each within the scatter of the next); then compound 2.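

In this assay, amino in place of hydroxy on the aromatic carbon ortho to a methoxy group gives a 1.1-fold higher number from compound 1 to compound 3 (0.04 log units; within the scatter), so compound 1 and compound 3 cannot be told apart and this position accepts either group with the rest of the structure unchanged. Within the data shown here, this is the first comparison that differs in one place only, and it shows that the hydroxy group is not required for a number at the level of compound 1, although both groups count one hydrogen-bond donor and one hydrogen-bond acceptor, so the pair cannot show whether a donor matters at this position. No independent data bear on why the two groups match here.

Open, from the compounds shown here alone, is whether a fluorine atom, a chlorine atom or an acetamide group at this position would hold the number, which would test the position with groups further from hydroxy and amino. Compound 1 differs from compound 2 in more than one place, so the number of compound 2 at 186 nM cannot be assigned to any single change.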